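Chloromethylbenzyl purines: removing the amino group

The source may hold more compounds than are shown below. What is called first, only, known or untested is meant among the compounds shown, and "the series" means these compounds.

Working notes on two chloromethylbenzyl compounds and one untested analogue. Compound 1 `Nc1nc(Cl)c2ncn(Cc3ccccc3CCl)c2n1` in a functional assay on SNB-75 cells (Homo sapiens) for cytotoxicity, read by sulforhodamine B assay, with a stated time of 48 h (on this read-out lower numbers stand for stronger inhibition of growth and higher numbers for weaker inhibition of growth), gives 8130 nM. Going by the values given here, compound 2 `Nc1nc(Cl)c2ncn(Cc3cccc(CCl)c3)c2n1` in this assay gives 5750 nM, which lies within the scatter of compound 1; no steps between measured pairs are known here. Compound 3 `ClCc1ccccc1Cn1cnc2c(Cl)ncnc21` carries the change hydrogen in place of amino on an aromatic carbon relative to compound 1. With nothing measured for this kind of change in the series, the expected step is small, at most a slight weakening, and essentially a 1.2-fold higher number from compound 1 to compound 3 (0.09 log units; within the scatter) in this assay. Compound 3 is therefore estimated at 10000 nM, with a range from 3000 nM to 35000 nM.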

Compound 3, concentration for 50% growth inhibition: 2880 nM
Estimate against measurement, compound 3: 3.5-fold (0.54 log units) above, outside the stated range (below it).
By their numbers in this assay, from the lowest: compounds 3, 2 and 1 (each within the scatter of the next, the first and the last beyond it).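

In this assay, hydrogen in place of amino on the aromatic carbon between two ring nitrogen atoms gives a 2.8-fold lower number from compound 1 to compound 3 (0.45 log units; beyond the scatter), a modest step and the first one readable in this series. The amino group is therefore not required for growth inhibition on the core of compound 1, and growth inhibition is stronger without it. Nothing available bears on the reason for this step.

The compounds shown leave open whether the same change gives a similar step with the chloromethyl group placed as in compound 2. They also leave open what a methylamino or hydroxyl group would give on that carbon.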